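A Butoxy Group Added to Compound 2

The compounds below may be only part of what the source reports. "The series", "measured", "known", "first", "only" and "open" are said of these compounds alone.

Measured in a functional assay on HL-60 cells (Homo sapiens) for cytotoxicity, read by WST assay, with a stated time of 48 h; a higher number here means that more compound is needed for the effect, a lower number that less compound is needed:
Compound 1 `Cc1ccccc1C[C@H]1C(=O)OC[C@@H]1Cc1ccccc1`: 57000 nM
Compound 2 `O=C1OC[C@H](Cc2ccccc2)[C@H]1Cc1ccc(O)cc1`: 88000 nM
Compound 3 `COc1ccc(C[C@H]2C(=O)OC[C@@H]2Cc2ccccc2)cc1`: 67000 nM

Compound 2, at 88000 nM, cannot be separated from the other two compounds. The measured steps that reach it are a 1.5-fold higher number from compound 1 to compound 2 (0.19 log units; within the scatter) and a 1.3-fold lower number from compound 2 to compound 3 (0.12 log units; within the scatter), and both stay within the usual scatter. In this small set, this assay therefore gives no clear ordering of the three compounds.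

Compound 4 `CCCCOc1cc(C[C@H]2C(=O)OC[C@@H]2Cc2ccccc2)ccc1O` has not yet been measured. It carries butoxy in place of hydrogen on an aromatic carbon of compound 2: butoxy in place of hydrogen on an aromatic carbon. Its hydroxy group remains in place. Among the compounds with values here, no measured step adds a group at this position, so the data offer no direct precedent. The closest comparison is the methyl on oxygen in a 1.3-fold lower number from compound 2 to compound 3 (0.12 log units; within the scatter), a different change at a different place on the ring. Neither measured step shows a clear effect, but butoxy is a larger addition than that methyl, so only a modest fall in the number is tentatively expected, and a result within the scatter would be no surprise.

The estimated change is a 2.5-fold lower number from compound 2 to compound 4 (0.40 log units; beyond the scatter).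

For compound 4 the expected value is 35000 nM, with an estimated range from 12000 nM to 90000 nM.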

Compound 4, half-maximal effective concentration: 35000 nM
Estimate against measurement, compound 4: no gap at the digits printed, and the stated range covers the measured number.
By their numbers in this assay, from the lowest: compounds 4, 1, 3 and 2 (each within the scatter of the next, the first and the last beyond it).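

In this assay, within the data shown here, butoxy on an aromatic carbon, ortho to a hydroxy group, gives a 2.5-fold lower number from compound 2 to compound 4 (0.40 log units; beyond the scatter), the only step in this set that lies beyond the usual scatter. The two earlier steps, one exchanging the whole substituted phenyl group and one placing methyl on the oxygen, both stayed within the scatter, so this carbon is the first place shown where a change separates two compounds, though only modestly. Nothing in the available data accounts for the lower number seen with butoxy at this place.

As far as these compounds go, it remains open whether this step depends on butoxy itself or would also follow from another group on the same carbon, such as methoxy, a longer chain like hexyloxy, or an amine. From the compounds shown here alone, it is equally open whether the step depends on the hydroxy group that compound 4 retains, a question that a compound with butoxy at this place and methoxy in place of that hydroxy group could address.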